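Sulfonamide aryl swap toward a fluorinated analogue

This account rests on a few compounds, and the source may have more. Where it says the series, first, only, none or still open, it means among the compounds named here.

Compound 1 `Cc1ccc(S(=O)(=O)N[C@H]2CCN(CCCOc3ccc(C(=O)C4CC4)cc3)C2)cc1`: 380 nM
Compound 2 `N#Cc1ccc(S(=O)(=O)N[C@H]2CCN(CCCOc3ccc(C(=O)C4CC4)cc3)C2)cc1`: 1600 nM

In an assay on isolated protein for binding affinity to histamine H2 receptor (Homo sapiens) (on this read-out lower numbers stand for stronger inhibition and higher numbers for weaker inhibition), compound 2 gives the highest of the two numbers; its nearest neighbour is compound 1, separated by a 4.2-fold higher number from compound 1 to compound 2 (0.62 log units; beyond the scatter). Compound 3 `O=C(c1ccc(OCCCN2CC[C@H](NS(=O)(=O)c3ccccc3F)C2)cc1)C1CC1` differs from compound 2 by 2-fluorophenyl in place of 4-cyanophenyl on a sulfonyl sulfur. Among the compounds with values here, the only step that bears on this change is the one from compound 1 to compound 2, which removed a methyl for a cyano and weakened binding; the cyano now leaves again. Compound 3 is therefore expected to return part of that loss, a step of a 2.9-fold lower number from compound 2 to compound 3 (0.46 log units; beyond the scatter), giving an estimate of 550 nM with a range of 150 nM to 2000 nM.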

Compound 3, inhibition constant: 1550 nM
Beside the measured number, compound 3's estimate is 2.8-fold (0.45 log units) below it; low and high end bracket the measured number.
By their numbers in this assay, from the lowest: compound 1; then compounds 3 and 2 (each within the scatter of the next).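

In this assay, 2-fluorophenyl in place of 4-cyanophenyl on a sulfonyl sulfur gives a 1.0-fold lower number from compound 2 to compound 3 (0.01 log units; within the scatter), so this assay does not separate these two groups. The 4-methylphenyl group remains apart from 2-fluorophenyl, with a 4.1-fold higher number from compound 1 to compound 3 (0.61 log units; beyond the scatter), so the earlier cyano step is not a peculiarity of the nitrile alone. Nothing available explains this result.

The compounds shown leave open whether the methyl itself or its place on the ring matters. A 2-methylphenyl or a 4-fluorophenyl group on the sulfonyl sulfur would separate these two readings.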